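The compounds below may be only part of what the source reports. "The series", "measured", "known", "first", "only" and "open" are said of these compounds alone.

Compound 1 `CCn1c(C(=O)NC(C)(C)CO)ccc1C(CC)(CC)c1ccc(OCS(=O)(=O)c2ccccc2)c(C)c1` serves as the reference point of this small set. In a functional assay on BXPC-3 cells (Homo sapiens) for antiproliferative activity, read by MTT assay, with a stated time of 24 h (on this read-out higher numbers stand for weaker inhibition and lower numbers for stronger inhibition), compound 1 gives 18300 nM, the lowest of the three numbers recorded so far. Compound 2 `CCn1c(C(=O)NC2(CO)CC2)ccc1C(CC)(CC)c1ccc(OCS(=O)(=O)c2ccccc2)c(C)c1` gives 45400 nM in the same assay, and compound 3 `CCn1c(C(=O)N[C@@H](C)C(=O)O)ccc1C(CC)(CC)c1ccc(OCS(=O)(=O)c2ccccc2)c(C)c1` gives 20800 nM. The move from compound 1 to compound 2 brought a 2.5-fold higher number from compound 1 to compound 2 (0.39 log units; beyond the scatter), whereas the move from compound 1 to compound 3 brought only a 1.1-fold higher number from compound 1 to compound 3 (0.06 log units; within the scatter), so 1-carboxyethyl in place of 1-(hydroxymethyl)-1-methylethyl carried no change beyond the scatter.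

Compound 4 `CCn1c(C(=O)NCCC(=O)O)ccc1C(CC)(CC)c1ccc(OCS(=O)(=O)c2ccccc2)c(C)c1` has not yet been measured. It differs from compound 1 by 2-carboxyethyl in place of 1-(hydroxymethyl)-1-methylethyl on an amide-type nitrogen. Among the compounds with values here, the step that bears most on this is the one to compound 3, where a carboxylic acid likewise entered on the amide-type nitrogen and the number moved only a 1.1-fold higher number from compound 1 to compound 3 (0.06 log units; within the scatter); the step to compound 2, with a 2.5-fold higher number from compound 1 to compound 2 (0.39 log units; beyond the scatter), brought a 1-(hydroxymethyl)cyclopropyl group instead and is less comparable. Compound 4 is therefore expected to show a 1.2-fold higher number from compound 1 to compound 4 (0.08 log units; within the scatter), nothing beyond the scatter. Compound 4 is estimated at 22000 nM, with a range from 10000 nM to 48000 nM.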

Compound 4, half-maximal inhibitory concentration: > 50000 nM
Compound 4 ended at the assay's limit (the forecaster's own chance of this, stated with the estimate: 5%); middle value at least 2.2-fold (0.35 log units) away from the limit.
By their numbers in this assay, from the lowest: compounds 1 and 3 (each within the scatter of the next); then compound 2. At a limit, above all of these: compound 4.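

In this assay compound 4 gives > 50000 nM, which is a limit of the assay and not a number: the limit of > 50000 nM in this assay, at which 1 of the 4 values shown sits.

Within the data shown here, on the amide-type nitrogen, then, a carboxylic acid does not always leave the number unchanged: 2-carboxyethyl in place of 1-(hydroxymethyl)-1-methylethyl brings an at least 2.7-fold higher number from compound 1 to compound 4 (0.43 log units; beyond the scatter), and moving from 1-carboxyethyl to 2-carboxyethyl brings an at least 2.4-fold higher number from compound 3 to compound 4 (0.38 log units; beyond the scatter), so the arrangement of the acid-bearing chain matters here, which the earlier compounds did not show. Against 1-(hydroxymethyl)cyclopropyl, the change gives an at least 1.1-fold higher number from compound 2 to compound 4 (0.04 log units; that floor lies within the scatter), a floor that leaves those two compounds unordered.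

The compounds shown leave open whether a longer chain ending in a carboxylic acid, or a 2-aminoethyl group in place of 2-carboxyethyl, would stay at this limit or return towards compound 1. Going by these compounds, the actual value of compound 4 also remains open.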